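Inverting one stereocentre of compound 3

The compounds below may be only part of what the source reports. "The series", "measured", "known", "first", "only" and "open" are said of these compounds alone.

Compound 1 (`C=C/C=C\[C@H](C)[C@H](OC(N)=O)[C@@H](C)[C@H](O)[C@@H](C)C/C(C)=C\[C@H](C)[C@@H](O)[C@@H](C)/C=C\[C@@H](O)C[C@@H]1OC(=O)[C@H](C)[C@@H](O[Si](C)(C)C(C)(C)C)[C@H]1C`): (790 nM)
Compound 2 (`C=C/C=C\[C@H](C)[C@H](OC(N)=O)[C@@H](C)[C@H](O)[C@@H](C)CC(=C)[C@H]1[C@H](C)[C@@H](O)[C@@H](C)[C@@H]1/C=C/C[C@@H]1OC(=O)[C@H](C)[C@@H](O)[C@H]1C`): (190 nM)
Compound 3 (`C=C/C=C\[C@H](C)[C@H](OC(N)=O)[C@@H](C)[C@H](O)[C@@H](C)C[C@@](C)(O)[C@H]1[C@H](C)[C@@H](O)[C@@H](C)[C@@H]1/C=C/C[C@@H]1OC(=O)[C@H](C)[C@@H](O)[C@H]1C`): (2420 nM)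

All three values come from a functional assay on P388 cells (Mus musculus) for cytotoxicity; a lower number here means a stronger inhibitor, a higher number a weaker inhibitor. Compound 3 has the highest number of the three, which makes it the weakest, and compound 1 and compound 2 both lie lower by more than the usual scatter. Compound 4 (`C=C/C=C\[C@H](C)[C@H](OC(N)=O)[C@@H](C)[C@H](O)[C@@H](C)C[C@](C)(O)[C@H]1[C@H](C)[C@@H](O)[C@@H](C)[C@@H]1/C=C/C[C@@H]1OC(=O)[C@H](C)[C@@H](O)[C@H]1C`) differs from compound 3 only in its spatial arrangement: the two compounds have the same atoms and bonds and differ only in configuration as drawn: 1 of 17 stereo elements differ; a stereocentre at a saturated chain carbon is drawn R in compound 3 and S in compound 4. A stereocentre at a saturated chain carbon is drawn R in compound 3 and S in compound 4. Going by the values given here, no measured pair shows such an inversion on its own, so this expectation is uncertain. In this assay a modest fall is expected, because compound 3 at (2420 nM) already stands highest. The estimated change is a 2.4-fold lower number from compound 3 to compound 4 (0.38 log units; beyond the scatter), a step toward a lower number. For compound 4 the expected value is 1000 nM, with an estimated range from 200 nM to 4000 nM.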

Compound 4, half-maximal inhibitory concentration: 2090 nM
Beside the measured number, compound 4's estimate is 2.1-fold (0.32 log units) below it; the measured number falls inside the stated range.
By their numbers in this assay, from the lowest: compound 2; then compound 1; then compounds 4 and 3 (each within the scatter of the next).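

In this assay, inverting the stereocentre at this saturated chain carbon from R to S gives a 1.2-fold lower number from compound 3 to compound 4 (0.06 log units; within the scatter). Going by these compounds alone, this is the first inversion measured on its own, and the two numbers lie within the usual scatter of each other. The step speaks for this one stereocentre alone because nothing else in the structure changes: the fact that compounds 3 and 4 differ only in the configuration as drawn

Still open, going by these compounds, is whether a group other than the hydroxyl on this carbon, such as an amine or a methyl ether, would show the same indifference to configuration. This single pair also says nothing about the other stereocentres.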